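Lengthening the chain from compound 2 to compound 3

This account rests on a few compounds, and the source may have more. Where it says the series, first, only, none or still open, it means among the compounds named here.

In a functional assay on PC-3 cells (Homo sapiens) for antiproliferative activity, read by MTT assay, with a stated time of 72 h (on this read-out higher numbers stand for weaker inhibition and lower numbers for stronger inhibition), compound 1 (`CCCCCCCCCCCCNC[C@@H]1OC[C@H](N)[C@@H]1O`) gives 850 nM and compound 2 (`CCCCCCCCCNC[C@@H]1OC[C@H](N)[C@@H]1O`) gives 2030 nM as the higher of the two numbers. Compound 3 (`CCCCCCCCCCCCCCNC[C@@H]1OC[C@H](N)[C@@H]1O`) carries pentyl in place of hydrogen on a saturated chain carbon, nine bonds along the chain from an amine nitrogen relative to compound 2, that is, pentyl in place of hydrogen on a saturated chain carbon, nine bonds along the chain from an amine nitrogen. For the measured compounds named here, one measured step bears on this, at the same place: with hydrogen in place of propyl there is a 2.4-fold higher number from compound 1 to compound 2 (0.38 log units; beyond the scatter) as a modest change. Read backwards, it ties a group on that carbon to a lower number, and pentyl is the larger group, though a single step fixes no trend. A modest step to a lower number is therefore expected in this assay for this change. The expected change is a 3.1-fold lower number from compound 2 to compound 3 (0.49 log units; beyond the scatter) in this estimate. For compound 3 the estimated value is 650 nM with an expected range of 300 nM to 1400 nM around it.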

Compound 3, half-maximal inhibitory concentration: 1200 nM
For compound 3 the middle estimate is 1.8-fold (0.27 log units) below the measured one; measured number inside the range.
By their numbers in this assay, from the lowest: compounds 1, 3 and 2 (each within the scatter of the next, the first and the last beyond it).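

In this assay, pentyl in place of hydrogen on this carbon leaves the longer chain not clearly separated from the shorter one (a 1.7-fold lower number from compound 2 to compound 3 (0.23 log units; within the scatter)). Ethyl in place of hydrogen on a saturated chain carbon likewise gives no separation (a 1.4-fold higher number from compound 1 to compound 3 (0.15 log units; within the scatter)). For the compounds shown here, the only step in the set beyond the scatter is therefore the one between the two compounds at the ends of the ranking (a 2.4-fold higher number from compound 1 to compound 2 (0.38 log units; beyond the scatter)), and lengthening the chain beyond that of compound 1 brings no measurable gain, so the three compounds show no graded trend with chain length.

Nothing at hand explains why the numbers flatten out here. Going by these compounds, whether a still longer chain, or an amine or a carboxylic acid on this chain, would move the number remains open.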